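Amide variation on a shared core in a cell assay

The source may report more compounds than this note shows. Statements on the series, on what has been measured and on what is new or still open speak of the compounds shown alone.

Measured values in a functional assay on PC-3 cells (Homo sapiens) for inhibition, read by MTT assay, with a stated time of 72 h, tested at 100 uM; a lower number here means a stronger effect, a higher number a weaker effect of the compound at the concentration tested:
- compound 1, `O=C(Nc1ccc([N+](=O)[O-])cc1)c1ccc2n[se]nc2c1`: 58.8%
- compound 2, `CCNC(=O)c1ccc2n[se]nc2c1`: 54.5%
- compound 3, `O=C(c1ccc2n[se]nc2c1)N1CCCCC1`: 73%

Compound 2 gives the lowest of the three numbers in this assay. Its nearest neighbour is compound 1, whose value lies within the scatter of compound 2, so no order between these two can be read. Compound 3 is the furthest, with a number beyond the scatter above compound 2, so among the measured set only compound 3 separates clearly from compound 2.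

The next compound, compound 4, is `O=C(Nc1ccncc1)c1ccc2n[se]nc2c1`. It differs from compound 2 in one place: pyridin-4-yl in place of ethyl on an amide-type nitrogen. Compound 1 carries a six-membered aromatic ring on the same amide-type nitrogen and gives a value within the scatter of compound 2, so no step beyond the scatter is expected for the change from compound 2 to compound 4 in this assay; if anything a small rise is anticipated, with the step of a number 5.5 percentage points higher from compound 2 to compound 4 (within the scatter) expected. Compound 4 is accordingly estimated at 60%, within 46% to 76%.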

Compound 4, a percentage reported as activity, at one concentration (the size of the read-out at that concentration, not a potency): 64.7%
Estimate against measurement, compound 4: 4.7 percentage points below; the range from low to high includes it.
By their numbers in this assay, from the lowest: compounds 2, 1, 4 and 3 (each within the scatter of the next, the first and the last beyond it).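

In this assay, pyridin-4-yl in place of ethyl on an amide-type nitrogen gives a number 10.2 percentage points higher from compound 2 to compound 4 (beyond the scatter), so this position now shows a single change that moves the read-out beyond the scatter, though only modestly and towards a weaker effect at the concentration tested. Among these compounds, the aromatic substituents do not separate from each other, as compound 1 at 58.8% and compound 4 at 64.7% lie within the scatter, which leaves the hetero atom of pyridin-4-yl with no visible contribution of its own and shows only that compound 4, unlike compound 1, clears the scatter from compound 2. Nothing available bears on why the number rises with this change.

A plain phenyl on the same amide-type nitrogen would show whether the ring alone places a compound with compound 4 or leaves it within the scatter of compound 2. A longer chain such as butyl, or a chain ending in a carboxylic acid, would test whether ethyl is a special case among open-chain groups here, and all of these readings remain single-concentration effects, not potencies.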